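Swapping Ester for Amide on the Most Active Compound

The compounds below may be only part of what the source reports. "The series", "measured", "known", "first", "only" and "open" are said of these compounds alone.

Measured in a functional assay on HCT-116 cells (Homo sapiens) for inhibition, read by MTT assay, with a stated time of 72 h; on this read-out higher numbers stand for weaker inhibition of growth and lower numbers for stronger inhibition of growth:
- compound 1 `CCOC(=O)/C=C/c1ccncc1-c1ccc2[nH]ccc2c1` gives 4830 nM
- compound 2 `CCOC(=O)/C=C/c1ccncc1-c1ccc2c(ccn2C)c1` gives 210 nM
- compound 3 `O=C(O)/C=C/c1ccncc1-c1ccc2cc[nH]c2c1` gives > 30000 nM, which is a limit

Of the exact numbers, the lowest belongs to compound 2. Among the measured compounds shown here, the only measured step, a 23-fold lower number from compound 1 to compound 2 (1.36 log units; beyond the scatter), is methyl in place of hydrogen on an aromatic nitrogen, so it does not touch the site now in question.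

Compound 4 `CNC(=O)/C=C/c1ccncc1-c1ccc2c(ccn2C)c1` carries methylamino in place of ethoxy on a carbonyl carbon. For the measured compounds named here, no measured step makes this change. Compound 3, which also lacks ethoxy but differs elsewhere too, gives only a limit, > 30000 nM. On that slim hint, a move toward a higher number in this assay is expected, with an estimated 4.3-fold higher number from compound 2 to compound 4 (0.63 log units; beyond the scatter). For compound 4 the estimate is 900 nM, with an expected range of 150 nM to 6000 nM.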

Compound 4, concentration for 50% growth inhibition: 4450 nM
Compound 4: middle estimate off by 4.9-fold (0.69 log units), on the low side; the measured number falls inside the stated range.
By their numbers in this assay, from the lowest: compound 2; then compounds 4 and 1 (each within the scatter of the next). At a limit, above all of these: compound 3.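

In this assay, methylamino in place of ethoxy on a carbonyl carbon gives a 21-fold higher number from compound 2 to compound 4 (1.33 log units; beyond the scatter) and is a large step. Among the compounds shown here, the earlier compounds offered a single exact step, at the aromatic nitrogen, so this is the first exact evidence that the number also depends strongly on the group at this carbonyl carbon. Nothing shown gives a cause for this step.

Going by these compounds, whether propoxy or dimethylamino on the same carbonyl carbon would stay close to compound 2 remains open. So does whether methylamino brings a similar step when hydrogen sits on the aromatic nitrogen.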